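Trimming One Propyl Chain to Methyl on the Shared Core

The source may report more compounds than this note shows. Statements on the series, on what has been measured and on what is new or still open speak of the compounds shown alone.

Compound 1, `CCCC1=C(N2CC2)C(=O)C(CCC)=C(N2CC2)C1=O`: 95.6%
Compound 2, `CC(C)C1=C(N2CC2)C(=O)C(C(C)C)=C(N2CC2)C1=O`: 0%

In a functional assay with Nucleic Acid as the target, tested at 100 uM (a higher number here means a stronger effect of the compound at the concentration tested, a lower number a weaker effect), compound 1 gives 95.6%, the higher of the two numbers, while compound 2 gives 0%, a gap beyond the usual scatter. Compound 3, `CCCC1=C(N2CC2)C(=O)C(C)=C(N2CC2)C1=O`, is not yet measured and differs from compound 1 in one place: hydrogen in place of ethyl on a saturated chain carbon bound to a double-bonded ring carbon. For the measured compounds named here, no pair of measured compounds shows this change, so its effect is unknown. A moderate loss in this assay is expected, with the estimated step being a number 30.6 percentage points lower from compound 1 to compound 3 (beyond the scatter). Compound 3 is therefore estimated at 65%, within a range from 15% to 98%.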

Compound 3, a percentage reported as activity, at one concentration (the size of the read-out at that concentration, not a potency): 100%
Compound 3: middle estimate off by 35 percentage points, on the low side, outside the stated range (above it).
By their numbers in this assay, from the lowest: compound 2; then compounds 1 and 3 (each within the scatter of the next).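

Trimming propyl to methyl on this saturated chain carbon bound to a double-bonded ring carbon leaves the read-out in this assay effectively unchanged, with a number 4.4 percentage points higher from compound 1 to compound 3 (within the scatter) as the step. The full propyl chain at this place is therefore not needed to keep the effect at the concentration tested. Nothing available explains this tolerance.

From the compounds shown here alone, whether a bare hydrogen or a longer chain such as butyl would be tolerated at this place stays open. So does whether the remaining propyl chain can be trimmed to methyl as well.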